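Cyclohexyl in place of isopropyl: what to expect of compound 4

The compounds below may be only part of what the source reports. "The series", "measured", "known", "first", "only" and "open" are said of these compounds alone.

Compound 3 `CC(C)c1cc[n+]([O-])cc1Oc1ccccc1` gives the lowest of the two numbers shown in a functional assay on the whole organism with Mus musculus as the target, in the maximal electroshock model, with a stated time of 30 min (a lower number here means that less compound is needed, a higher number that more compound is needed for the effect), 30 mg/kg. Compound 2 `O=Cc1cc[n+]([O-])cc1Oc1ccccc1` gives 300 mg/kg, and a 10-fold lower number from compound 2 to compound 3 (1.00 log units; beyond the scatter). Compound 1 `[O-][n+]1ccc(Cl)c(Oc2ccccc2)c1` reaches only a limit of the assay, > 300 mg/kg. The other two steps shown are a number no higher from compound 1 to compound 2 (the limit leaves the size open) and an at least 10-fold lower number from compound 1 to compound 3 (1.00 log units; beyond the scatter). Compound 4 `[O-][n+]1ccc(C2CCCCC2)c(Oc2ccccc2)c1` differs from compound 3 by cyclohexyl in place of isopropyl on an aromatic carbon. No measured step sets one alkyl group against another: the steps shown replace chloro or formyl by isopropyl, so none bears directly on the cyclohexyl change. A step within the scatter is therefore expected, no change at the digits printed from compound 3 to compound 4 (within the scatter). Compound 4 is estimated at 30 mg/kg, with a range from 10 mg/kg to 100 mg/kg.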

Compound 4, minimum effective dose: > 300 mg/kg
Compound 4 was reported as a limit; the forecaster's own chance of this, stated with the estimate: 10%; at least 10-fold (1.00 log units) between middle value and limit.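

In this assay, alkyl groups at this position are not interchangeable: cyclohexyl in place of isopropyl gives an at least 10-fold higher number from compound 3 to compound 4 (1.00 log units; beyond the scatter). The advantage of isopropyl over formyl is lost with cyclohexyl, which gives a number no lower from compound 2 to compound 4 (the limit leaves the size open). Compound 4 rests at a limit of the assay, as does compound 1, so the step between them cannot be read: the limit of > 300 mg/kg in this assay, at which 2 of the 4 values shown sit.

From the compounds shown here alone, it remains open whether the ring of cyclohexyl or its larger carbon count matters more. A hexyl chain, a cyclopropyl group or an amine at this position would help separate these.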